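The compounds below may be only part of what the source reports. "The series", "measured", "known", "first", "only" and "open" are said of these compounds alone.

In an assay for inhibition of Fatty-acid amide hydrolase 1 (Rattus norvegicus) (a higher number here means a weaker inhibitor, a lower number a stronger inhibitor), compound 1 `COC(=O)c1ccccc1CCCCCCC(=O)c1ncc(-c2ccccn2)o1` gives 1 nM. Compound 2 `O=C(CCCCCCc1ccccc1C(=O)O)c1ncc(-c2ccccn2)o1` gives > 600 nM, which is a limit of this assay. Compound 3 `O=C(CCCCCCc1cccnc1)c1ncc(-c2ccccn2)o1` gives 32 nM.

Compound 2 therefore stands at the limit of > 600 nM in this assay, at which 1 of the 3 values shown sits, with no exact number. Compound 4 `CS(=O)(=O)c1ccccc1CCCCCCC(=O)c1ncc(-c2ccccn2)o1` differs from compound 2 by methylsulfonyl in place of carboxy on an aromatic carbon. Among the compounds with values here, two measured steps bear on this change. Replacing the methyl of the ester with hydrogen gave an at least 600-fold higher number from compound 1 to compound 2 (2.77 log units; beyond the scatter), and replacing the 2-carboxyphenyl with pyridin-3-yl gave an at least 18-fold lower number from compound 2 to compound 3 (1.27 log units; beyond the scatter); in both, the compound carrying the carboxy is the far weaker one. Since the carboxy leaves in compound 4, a large step downward is expected, an at least 60-fold lower number from compound 2 to compound 4 (1.77 log units; beyond the scatter). Compound 4 is estimated at 10 nM, between 2 nM and 80 nM.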

Compound 4, inhibition constant: 37 nM
For compound 4 the middle estimate is 3.7-fold (0.57 log units) below the measured one; measured number inside the range.
By their numbers in this assay, from the lowest: compound 1; then compounds 3 and 4 (each within the scatter of the next). At a limit, above all of these: compound 2.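

On this aromatic carbon, methylsulfonyl in place of carboxy gives an at least 16-fold lower number from compound 2 to compound 4 (1.20 log units; beyond the scatter), so a group other than the ester can stand there without the full loss seen with carboxy. Methylsulfonyl does not match the ester, however: putting it in place of methoxycarbonyl gives a 37-fold higher number from compound 1 to compound 4 (1.57 log units; beyond the scatter). The figure for compound 2 remains a limit, not an exact number: the limit of > 600 nM in this assay, at which 1 of the 4 values shown sits.

Going by these compounds, whether an amide or a nitrile on this aromatic carbon would stand closer to compound 1 or to compound 4 stays open. So does whether methylsulfonyl would give a similar result on another carbon of that ring.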